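Trading an Acetyl for a Dimethylamino on the Outer Ring

The source may report more compounds than this note shows. Statements on the series, on what has been measured and on what is new or still open speak of the compounds shown alone.

Compound 1 `COc1cc(C)cc(-c2c(-c3ccnc(-c4ccc(C(C)=O)cc4)c3)cnn2CC#N)c1` carries an acetyl group on its outer phenyl ring. In a functional assay on SK-OV-3 cells (Homo sapiens) for inhibition, read by sulforhodamine B assay, with a stated time of 48 h (on this read-out higher numbers stand for weaker inhibition of growth and lower numbers for stronger inhibition of growth), compound 1 gives only > 100000 nM, which is a limit of the assay rather than a number, so its position is known only as the limit of > 100000 nM in this assay, at which 1 of the 3 values shown sits. Two relatives with a hydroxy in place of the methoxy on the other aryl ring have been measured in this assay: compound 2 `Cc1cc(O)cc(-c2nn(CC#N)cc2-c2ccnc(-c3ccc(Oc4ccccc4)cc3)c2)c1` gives 24400 nM, and compound 3 `Cc1cc(O)cc(-c2nn(CC#N)cc2-c2ccnc(-c3ccc(N(C)C)cc3)c2)c1`, which carries dimethylamino, gives 8030 nM. The step of a 3.0-fold lower number from compound 2 to compound 3 (0.48 log units; beyond the scatter) is the only measured move onto a dimethylamino group. Compound 4 `COc1cc(C)cc(-c2c(-c3ccnc(-c4ccc(N(C)C)cc4)c3)cnn2CC#N)c1` is compound 1 with dimethylamino in place of acetyl on an aromatic carbon. The measured step starts from phenoxy rather than acetyl, so it bears only loosely on this change, and the limit for compound 1 leaves the size of any step open. Compound 4 is nevertheless expected to reach a lower number than compound 1, with an at least 3.3-fold lower number from compound 1 to compound 4 (0.52 log units; beyond the scatter) as the expected step. The estimate for compound 4 is 30000 nM, with a range from 8000 nM to 100000 nM.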

Compound 4, concentration for total growth inhibition: > 100000 nM
Compound 4: a limit, no number (the forecaster's own chance of this, stated with the estimate: 35%); middle value at least 3.3-fold (0.52 log units) away from the limit.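

For the compounds shown here, compound 1 and compound 4 both give a limit of the assay rather than a number, so no step between them can be read: the limit of > 100000 nM in this assay, at which 2 of the 4 values shown sit. Left open is how far each lies past that limit in this assay and whether dimethylamino in place of acetyl changes growth inhibition at all.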